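The source may report more compounds than this note shows. Statements on the series, on what has been measured and on what is new or still open speak of the compounds shown alone.

Compound 1: `O=C(Nc1ccc(Sc2nc3ccccc3s2)cc1)c1cc(Br)cc(Br)c1`  — > 100000 nM
Compound 2: `O=C(Nc1ccc(Sc2nc3ccccc3s2)cc1)c1cc(Br)cc(Br)c1O`  — 4700 nM

In an assay for inhibition of HSP60/HSP10 (Homo sapiens), with a stated time of 60 min (on this read-out lower numbers stand for stronger inhibition and higher numbers for weaker inhibition), compound 1 gives > 100000 nM, which is a limit of the assay and not a number, as the limit of > 100000 nM in this assay, at which 1 of the 2 values shown sits, records. Compound 2 gives 4700 nM in this assay. Compound 2 therefore holds the only number shown; the one further value is a limit. Going by the values given here, the single measured step, an at least 21-fold lower number from compound 1 to compound 2 (1.32 log units; beyond the scatter), shows that putting a hydroxy onto the shared core made a large difference.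

Compound 3, `COc1c(Br)cc(Br)cc1C(=O)Nc1ccc(Sc2nc3ccccc3s2)cc1`, differs from compound 2 by methyl in place of hydrogen on an oxygen on an aromatic ring. The hydroxy whose arrival brought the large gain is thus covered by a methyl. Among the compounds with values here, the step from compound 1 to compound 2 is the only evidence that bears on this change, and it suggests the free hydroxy matters. The number for compound 3 is therefore expected to be weaker, estimated at 40000 nM, within 8000 nM to 150000 nM. This corresponds to an expected step of an 8.5-fold higher number from compound 2 to compound 3 (0.93 log units; beyond the scatter).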

Compound 3, half-maximal inhibitory concentration: > 100000 nM
Compound 3: a limit, no number (the forecaster's own chance of this, stated with the estimate: 40%); at least 2.5-fold (0.39 log units) between middle value and limit.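

In this assay, the change from hydroxy to methoxy gives an at least 21-fold higher number from compound 2 to compound 3 (1.32 log units; beyond the scatter), so the gain that came with the hydroxy does not survive once a methyl sits on its oxygen. Among these compounds, then, an oxygen at this position is not enough on its own, and only compound 2, with the free hydroxy, gives a number. Compound 3 gives a limit and not a number, and the step from compound 1 to compound 3 cannot be read, with both compounds at the same limit: the limit of > 100000 nM in this assay, at which 2 of the 3 values shown sit.

The compounds shown leave open whether an amine or a carboxylic acid in place of the hydroxy would keep any of the gain. They also leave open whether the hydroxy would bring a gain on a core without the two bromo groups.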